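Aminoethyl thioether on the shared core: an expected step

The compounds below may be only part of what the source reports. "The series", "measured", "known", "first", "only" and "open" are said of these compounds alone.

Three analogues of one core have been measured in a functional assay on HT cells (Homo sapiens) for antiproliferative activity, read by fluorescence, with a stated time of 72 h; on this read-out higher numbers stand for weaker inhibition of growth and lower numbers for stronger inhibition of growth. Compound 1 `CC(C)c1n[nH]c2c(NCc3ccc(-c4ccccn4)cc3)nc(SCCNC(=N)N)nc12` gives 390 nM, compound 2 `CC(C)c1n[nH]c2c(NCc3ccc(-c4ccccn4)cc3)nc(SCC(N)=O)nc12` gives 192 nM, and compound 3 `CC(C)c1n[nH]c2c(NCc3ccc(-c4ccccn4)cc3)nc(SC(C)C(C)O)nc12` gives 190 nM. Within the data shown here, compound 3 therefore has the lowest number of the three; compound 2 lies within the scatter of it, and the only step beyond the scatter is a 2.1-fold lower number from compound 1 to compound 3 (0.31 log units; beyond the scatter). Compound 4 `CC(C)c1n[nH]c2c(NCc3ccc(-c4ccccn4)cc3)nc(SCCN)nc12` has not yet been measured. It differs from compound 3 in one place: 2-aminoethyl in place of 2-hydroxy-1-methylpropyl on a sulfur.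

Among the measured compounds shown here, the steps that bear on this change both start from compound 1, whose chain also carries nitrogen on a sulfur-bound chain. a 2.0-fold lower number from compound 1 to compound 2 (0.31 log units; beyond the scatter) and a 2.1-fold lower number from compound 1 to compound 3 (0.31 log units; beyond the scatter) were modest, and a 1.0-fold lower number from compound 2 to compound 3 (0.00 log units; within the scatter) showed that the two oxygen-bearing groups cannot be told apart. The 2-aminoethyl group of compound 4 is shorter than the chain of compound 1 and shares with it the nitrogen at the chain end, so compound 4 is expected to fall between compound 1 and compound 3, most likely within the scatter of compound 3 or a little above it. The expected step is a 1.4-fold higher number from compound 3 to compound 4 (0.14 log units; within the scatter). In this assay compound 4 is estimated at 260 nM, with a range from 110 nM to 620 nM.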

Compound 4, concentration for 50% growth inhibition: 22 nM
Compound 4: middle estimate off by 12-fold (1.07 log units), on the high side, and the stated range ends above it.
By their numbers in this assay, from the lowest: compound 4; then compounds 3 and 2 (each within the scatter of the next); then compound 1.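

In this assay, among these compounds, the group on the sulfur proves able to shift the read-out far more than the earlier compounds showed, as their small differences gave no hint of an 8.6-fold lower number from compound 3 to compound 4 (0.94 log units; beyond the scatter) or of an 8.7-fold lower number from compound 2 to compound 4 (0.94 log units; beyond the scatter). Nitrogen at the chain end does not by itself go with the highest number, since removing the group carried on the amine nitrogen of compound 1 gives an 18-fold lower number from compound 1 to compound 4 (1.25 log units; beyond the scatter), the largest step in the series, and leaves compound 4 with the strongest inhibition of growth of the four. No measurement shown here accounts for these steps.

The compounds shown leave open whether the lower number follows the free amine or the short chain, and a 2-hydroxyethyl group, which would keep the chain length and put oxygen in place of the nitrogen, would separate the two. Also open, going by these compounds, is how a longer chain such as 3-aminopropyl, a dimethylamine at the chain end, or a carboxylic acid there would read in this assay.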